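Moving the bromine around the ring in an enone series

A few compounds are considered here, and "the series" means these few. Any claim that something is new, unique, unknown or untested is made for them only; others in the source may bear on it.

Compound 2 `COc1ccc(/C=C2\CCC/C(=C\c3ccccc3Br)C2=O)cc1OC` carries a 2-bromophenyl on a double-bonded chain carbon bound to a double-bonded ring carbon. In a functional assay on A549 cells (Homo sapiens) for cytotoxicity, read by MTT assay, with a stated time of 72 h (on this read-out lower numbers stand for stronger inhibition and higher numbers for weaker inhibition), compound 2 reaches only a limit of > 20000 nM, so no exact number is known for it. Compound 1 `COc1ccc(/C=C2\CCC/C(=C\c3cccc(Cl)c3)C2=O)cc1OC` has a 3-chlorophenyl at that place instead and gives 11000 nM in this assay. Going by the values given here, the measured step of an at least 1.8-fold higher number from compound 1 to compound 2 (0.25 log units; that floor lies within the scatter) is the only comparison available, and it rests on a limit (the limit of > 20000 nM in this assay, at which 1 of the 2 values shown sits). Among the compounds with values here, compound 3 `COc1ccc(/C=C2\CCC/C(=C\c3ccc(Br)cc3)C2=O)cc1OC` is the next compound to be tested: 4-bromophenyl in place of 2-bromophenyl on a double-bonded chain carbon bound to a double-bonded ring carbon The two bromine-bearing compounds differ only in the bromophenyl group, and no measured step shows how such a change acts in this assay. Compound 3 is therefore expected to sit near the edge of what this assay resolves, at an estimated 15000 nM with a range from 5000 nM to 40000 nM. This estimate means a step of an at least 1.3-fold lower number from compound 2 to compound 3 (0.12 log units; that floor lies within the scatter) that is expected to stay within the scatter.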

Compound 3, half-maximal inhibitory concentration: 16000 nM
For compound 3 the middle estimate is 1.1-fold (0.03 log units) below the measured one, and the stated range covers the measured number.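

Going by these compounds alone, compound 3 gives the first exact number for a bromophenyl at this place in this assay, where compound 2 offers only a limit. From the compounds shown here alone, exchanging 2-bromophenyl for 4-bromophenyl gives an at least 1.2-fold lower number from compound 2 to compound 3 (0.09 log units; that floor lies within the scatter), so the compounds show no clear effect of this change, and the true size of the step stays unknown, as one of its ends is a limit: the limit of > 20000 nM in this assay, at which 1 of the 3 values shown sits. The step of a 1.5-fold higher number from compound 1 to compound 3 (0.16 log units; within the scatter) also stays within the scatter, so the 4-bromophenyl and the 3-chlorophenyl cannot be told apart in this assay.

The compounds shown leave open how a 3-bromophenyl would compare with these groups. They also leave open whether a phenyl carrying something other than a halogen, such as an amine or a carboxylic acid, would move the number clearly at this place.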